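Pyrazole to methoxypyridine: what compound 4 may show

The source may report more compounds than this note shows. Statements on the series, on what has been measured and on what is new or still open speak of the compounds shown alone.

Compound 1 `Cc1cncc(-c2noc([C@H](C)NC(=O)c3cc(C(F)(F)F)nn3C)n2)c1` gives 1370 nM
Compound 2 `C[C@H](NC(=O)c1cc(C(F)(F)F)nn1C)c1nc(-c2ccccn2)no1` gives > 30000 nM
Compound 3 `C[C@H](NC(=O)c1cc(C(F)(F)F)nn1C)c1nc(-c2cnn(C)c2)no1` gives 2640 nM

In an assay on T-REx-293 cells for inhibition of potassium channel subfamily T member 1 (Homo sapiens), read by patch clamp (on this read-out lower numbers stand for stronger inhibition and higher numbers for weaker inhibition), compound 3 has the highest of the two numbers, with compound 1 within the scatter of it. The value of compound 2 is a limit of the assay, not a number (the limit of > 30000 nM in this assay, at which 1 of the 3 values shown sits). Compound 4 `COc1cc(-c2noc([C@H](C)NC(=O)c3cc(C(F)(F)F)nn3C)n2)ccn1` differs from compound 3 by 2-methoxypyridin-4-yl in place of 1-methyl-1H-pyrazol-4-yl on an aromatic carbon. Among the compounds with values here, two measured steps bear on a six-membered ring at this position: a 1.9-fold higher number from compound 1 to compound 3 (0.28 log units; within the scatter) and an at least 11-fold lower number from compound 2 to compound 3 (1.05 log units; beyond the scatter). One six-membered ring sits close to compound 3, the other far weaker, so the direction is uncertain and a step beyond the scatter toward weaker inhibition is possible. Compound 4 is therefore estimated at 3500 nM, between 900 nM and 15000 nM, an expected step of a 1.3-fold higher number from compound 3 to compound 4 (0.12 log units; within the scatter).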

Compound 4, half-maximal inhibitory concentration: 27 nM
Compound 4: middle estimate off by 130-fold (2.11 log units), on the high side, and the stated range ends above it.
By their numbers in this assay, from the lowest: compound 4; then compounds 1 and 3 (each within the scatter of the next). At a limit, above all of these: compound 2.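

Within the data shown here, at this aromatic carbon, the choice of ring matters far more than the earlier compounds showed: 2-methoxypyridin-4-yl brings much stronger inhibition (a 98-fold lower number from compound 3 to compound 4 (1.99 log units; beyond the scatter); a 51-fold lower number from compound 1 to compound 4 (1.71 log units; beyond the scatter)). A six-membered ring here can therefore give strong inhibition, and compounds 1, 2 and 4 show that having a pyridine ring does not by itself set the outcome. The step from the pyridin-2-yl compound (an at least 1100-fold lower number from compound 2 to compound 4 (3.04 log units; beyond the scatter)) is only a minimum, and compound 2 has a limit, not a number: the limit of > 30000 nM in this assay, at which 1 of the 4 values shown sits. Still open, on these data alone, is how much of the gain depends on the methoxy group itself. An ethoxy group or an amine in its place could show this.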